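The source may hold more compounds than are shown below. What is called first, only, known or untested is meant among the compounds shown, and "the series" means these compounds.

Compound 1 `O=C(O)Cc1sc(C(c2ccccc2)c2ccc(Cl)cc2)nc1-c1ccc(Cl)cc1`: 80%
Compound 2 `O=C(O)Cc1sc(C(c2ccccc2)c2ccc(Cl)cc2)nc1-c1ccc(F)cc1`: 80%

Among the compounds with values here, in an in vitro functional assay on HEK285-7 cells for antagonist activity at prostaglandin D2 receptor 2 (Homo sapiens), read by BRET and beta-arrestin recruitment (on this read-out lower numbers stand for smaller maximal responses and higher numbers for larger maximal responses), compound 1 gives 80% and stands level with its nearest neighbour, compound 2, which gives 80%; the one measured step, no change at the digits printed from compound 1 to compound 2 (within the scatter), lies within the scatter. Compound 3 `O=C(O)Cc1sc(C(Cc2ccccc2)c2ccccc2)nc1-c1ccc(Cl)cc1` differs from compound 1 in a different place altogether: benzyl in place of 4-chlorophenyl on a saturated chain carbon bound to two aromatic carbons. Within the data shown here, no measured step touches this change, since the step from compound 1 to compound 2 swaps a halogen on the ring bound to the core, not a group on the saturated chain carbon. The two measured compounds only show that the maximal response held steady under one small change, so the expectation for compound 3 in this assay is a step of a number 5 percentage points lower from compound 1 to compound 3 (within the scatter), with a wide range to cover the lack of direct evidence. The estimate for compound 3 is therefore 75%, between 50% and 95%.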

Compound 3, largest response reached (reported as efficacy), in percent of the reference or control that the assay uses: 50%
Compound 3: middle estimate off by 25 percentage points, on the high side; the measured number falls inside the stated range.
By their numbers in this assay, from the lowest: compound 3; then compounds 1 and 2 (each within the scatter of the next).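

In this assay, the saturated chain carbon bound to two aromatic carbons proves sensitive to substitution: benzyl in place of 4-chlorophenyl gives a number 30 percentage points lower from compound 1 to compound 3 (beyond the scatter), whereas the earlier fluoro-for-chloro change gave no change at the digits printed from compound 1 to compound 2 (within the scatter). The size of this new step shows that the maximal response is not fixed across the series, even though the leaving and entering groups hold the same number of heavy atoms and each holds a single aromatic ring. Nothing available explains why the response moves with this change.

The change removes a chlorine and also adds a carbon to the link, so the compounds shown cannot say which of the two accompanies the step. A plain phenyl or a 4-chlorobenzyl on that carbon would separate the two.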